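A few compounds are considered here, and "the series" means these few. Any claim that something is new, unique, unknown or untested is made for them only; others in the source may bear on it.

Three quinazoline-bearing compounds share one core and carry a selenocyanate on a chain; they were tested in a functional assay on RKO cells (Homo sapiens) for inhibition, read by MTT assay, with a stated time of 48 h; on this read-out higher numbers stand for weaker inhibition and lower numbers for stronger inhibition. Compound 3 `COc1ccc(N(C)c2nc(C)nc3ccccc23)cc1OCCCC[Se]C#N` gives 1360 nM. Compound 1 `COc1ccc(N(C)c2nc(C)nc3ccccc23)cc1OCCCCCC[Se]C#N` differs from it by a group of 5 heavy atoms (3 carbon, 1 nitrogen, 1 selenium; no ring) in place of a group of 3 heavy atoms (1 carbon, 1 nitrogen, 1 selenium; no ring), on a saturated chain carbon, four bonds along the chain from an oxygen on an aromatic ring and gives 1540 nM, so the step is a 1.1-fold higher number from compound 3 to compound 1 (0.05 log units; within the scatter). Compound 2 `COc1ccc(N(C)c2nc(C)nc3ccccc23)cc1C(=O)OCCCC[Se]C#N` differs from compound 3 by a group of 10 heavy atoms (6 carbon, 1 nitrogen, 2 oxygen, 1 selenium; no ring) in place of a group of 8 heavy atoms (5 carbon, 1 nitrogen, 1 oxygen, 1 selenium; no ring), on an aromatic carbon, and in this assay compound 2 gives 1020 nM. The two steps that involve compound 2 are a 1.3-fold higher number from compound 2 to compound 3 (0.12 log units; within the scatter) and a 1.5-fold lower number from compound 1 to compound 2 (0.18 log units; within the scatter). All three numbers sit close together, and none of the steps stands apart from the ordinary spread of such measurements.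

Compound 4 `COc1ccc(N(C)c2nc(C)nc3ccccc23)cc1C(=O)OCCCCCC[Se]C#N` has not yet been measured. It differs from compound 2 by a group of 5 heavy atoms (3 carbon, 1 nitrogen, 1 selenium; no ring) in place of a group of 3 heavy atoms (1 carbon, 1 nitrogen, 1 selenium; no ring), on a saturated chain carbon, four bonds along the chain from an oxygen next to a carbonyl group. Going by the values given here, this is the same kind of change as the one from compound 3 to compound 1, though not the same: there the chain was lengthened four bonds along from an oxygen on an aromatic ring, here four bonds along from an oxygen next to a carbonyl group. Among the compounds with values here, the expected step in this assay is a 1.1-fold higher number from compound 2 to compound 4 (0.05 log units; within the scatter), placed beside the measured 1.1-fold higher number from compound 3 to compound 1 (0.05 log units; within the scatter) on which it rests, since that is the only instance of the lengthening among the measured compounds. Compound 4 is therefore estimated at 1150 nM, with a likely range from 600 nM to 2300 nM.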

Compound 4, half-maximal inhibitory concentration: 1990 nM
Compound 4: middle estimate off by 1.7-fold (0.24 log units), on the low side, and the stated range covers the measured number.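

Read in this assay, lengthening the chain that carries the selenocyanate on the core of compound 2 gives a 2.0-fold higher number from compound 2 to compound 4 (0.29 log units; within the scatter), a step that stays inside the ordinary spread of repeated measurements, as does the matching step on the other core. Set side by side, the two instances of this change cannot be told apart: the same change on two cores in this assay, a 1.1-fold higher number (0.05 log units; within the scatter) from compound 3 to compound 1 and a 2.0-fold higher number (0.29 log units; within the scatter) from compound 2 to compound 4, 1.7-fold (0.24 log units) apart, within the scatter of two such steps. So, on these two pairs, carrying the lengthening from one core to the other shows no detectable difference on this read-out; this does not show that the change has no effect at all, or that the two cores truly respond alike, and a small real difference could lie hidden in the scatter, while two pairs say nothing about any third core.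

All four compounds shown end in a selenocyanate and carry one of only two chain lengths, so they leave open what a still longer chain would do, and what would follow if a thiocyanate or a plain nitrile stood at the chain end instead. They also leave open whether the same picture would hold on cells other than the ones used here.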